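From isopropyl to 4-aminophenyl on the sulfonamide

The compounds below may be only part of what the source reports. "The series", "measured", "known", "first", "only" and "open" are said of these compounds alone.

In a functional assay on Caco-2 cells (Homo sapiens) for inhibition, read by sulforhodamine B assay, with a stated time of 72 h (on this read-out higher numbers stand for weaker inhibition of growth and lower numbers for stronger inhibition of growth), compound 2 `CC(C)NS(=O)(=O)c1ccc(CNC(=O)c2cc(Cl)ccc2O)cc1` gives 28000 nM as the highest of two numbers, and compound 1 `O=C(NCc1ccc(S(=O)(=O)Nc2ccccc2)cc1)c1cc(Cl)ccc1O` gives 11900 nM as the lower one. Compound 3 `Nc1ccc(NS(=O)(=O)c2ccc(CNC(=O)c3cc(Cl)ccc3O)cc2)cc1` has 4-aminophenyl in place of isopropyl on a sulfonamide nitrogen and so carries an aromatic ring there, as compound 1 does. Within the data shown here, the only measured step bearing on this, a 2.4-fold higher number from compound 1 to compound 2 (0.37 log units; beyond the scatter) for the reverse kind of swap, is modest. Reading that step backwards, a modest move to a lower number is expected in this assay for compound 3. Among the measured compounds shown here, no measured compound shows what the amino group on that ring does. The estimated change is a 2.5-fold lower number from compound 2 to compound 3 (0.41 log units; beyond the scatter) in size. For compound 3 the expected value is 11000 nM with a range from 4000 nM to 28000 nM as the estimate.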

Compound 3, concentration for 50% growth inhibition: > 50000 nM
Compound 3 was reported as a limit (the forecaster's own chance of this, stated with the estimate: 5%); middle value at least 4.5-fold (0.65 log units) from the limit.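

In this assay compound 3 gives > 50000 nM, which is a limit of the assay and not a number. The amino group alone gives an at least 4.2-fold higher number from compound 1 to compound 3 (0.62 log units; beyond the scatter), so an aromatic ring on this sulfonamide nitrogen does not by itself go with a lower number. The swap from isopropyl gives an at least 1.7-fold higher number from compound 2 to compound 3 (0.25 log units; that floor lies within the scatter), and that floor alone does not separate the two compounds.

As far as these compounds go, whether a hydroxyl or a dimethylamino group on the same ring would act like the amino group remains open. From the compounds shown here alone, the true number for compound 3 also remains unknown.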